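The compounds below may be only part of what the source reports. "The series", "measured", "known", "first", "only" and "open" are said of these compounds alone.

Measured so far in an assay on isolated protein for inhibition of steroid 5-alpha-reductase (Rattus norvegicus); on this read-out higher numbers stand for weaker inhibition and lower numbers for stronger inhibition:
compound 1 `COc1ccccc1N1CCN(CCC(Oc2ccc(NC(=O)c3ccccc3OCCCC(=O)O)cc2)c2ccccc2)CC1`, 730 nM;
compound 2 `COc1ccccc1N1CCN(CCC(Oc2ccc(NC(=O)c3ccccc3OCCCC(=O)O)cc2)c2ccc(CC(C)C)cc2)CC1`, 96 nM;
compound 3 `COc1ccccc1N1CCN(CCC(Oc2ccc(C(=O)Nc3ccccc3OCCCC(=O)O)cc2)c2cccc(C)c2)CC1`, 360 nM.

Compound 3 stands second highest of the three numbers in this assay, nearer to compound 1 than to compound 2. Compound 4 `COc1ccccc1N1CCN(CCC(Oc2ccc(C(=O)Nc3ccccc3OCCCC(=O)O)cc2)c2ccc(Br)cc2)CC1` has not yet been measured. It differs from compound 3 in one place: 4-bromophenyl in place of 3-methylphenyl on a saturated chain carbon bound to an oxygen on an aromatic ring and a saturated chain carbon. Within the data shown here, the only measured step bearing on this change is a 7.6-fold lower number from compound 1 to compound 2 (0.88 log units; beyond the scatter), where a group entering on the same aromatic ring lowered the number beyond the scatter. A step in the same direction but smaller is therefore expected, since bromine replaces a methyl rather than hydrogen, the estimated step being a 1.8-fold lower number from compound 3 to compound 4 (0.26 log units; within the scatter). For compound 4 in this assay the expected value is 200 nM, with a range from 70 nM to 600 nM.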

Compound 4, half-maximal inhibitory concentration: 210 nM
Compound 4: middle estimate off by 1.1-fold (0.02 log units), on the low side; the measured number falls inside the stated range.
By their numbers in this assay, from the lowest: compound 2; then compounds 4 and 3 (each within the scatter of the next); then compound 1.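

In this assay, 4-bromophenyl in place of 3-methylphenyl on a saturated chain carbon gives a 1.7-fold lower number from compound 3 to compound 4 (0.23 log units; within the scatter), so this exchange of one aromatic group for another of equal heavy-atom count does not separate compound 3 from compound 4. Unlike the isobutyl step, it leaves the two compounds indistinguishable on this read-out. No measurement here offers an explanation for this result.

The effect of swapping the substituent cannot be separated from that of moving it on the ring. As far as these compounds go, how isobutyl, chlorine or trifluoromethyl on this ring would behave with the core of compound 3 remains open.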